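Acetylsulfamoyl substitution on the core of compound 1

The source may report more compounds than this note shows. Statements on the series, on what has been measured and on what is new or still open speak of the compounds shown alone.

For the measured compounds named here, compound 1 `Oc1ccc(O)c(-c2cc(-c3ccccc3)nn2-c2ccccc2)c1` gives 63700 nM in a functional assay on cells (Cancer cell lines, Homo sapiens) for cytotoxicity, read by sulforhodamine B assay, with a stated time of 48 h (a higher number here means a weaker inhibitor of growth, a lower number a stronger inhibitor of growth), the highest of the two numbers in hand; compound 2 `Oc1ccc(O)c(-c2cc(-c3ccc(Cl)cc3)nn2-c2ccccc2)c1` gives 33200 nM, and the only measured step, a 1.9-fold lower number from compound 1 to compound 2 (0.28 log units; within the scatter), stays within the scatter. Compound 3 `CC(=O)NS(=O)(=O)c1ccc(-n2nc(-c3ccccc3)cc2-c2cc(O)ccc2O)cc1` carries acetylsulfamoyl in place of hydrogen on an aromatic carbon on an aromatic carbon of a six-membered aromatic ring of carbon only. Going by the values given here, no measured step touches this ring, and the one step known, a 1.9-fold lower number from compound 1 to compound 2 (0.28 log units; within the scatter), gives no reason to expect more than the scatter. Compound 3 is therefore expected near 50000 nM, between 18000 nM and 150000 nM, a step of a 1.3-fold lower number from compound 1 to compound 3 (0.11 log units; within the scatter).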

Compound 3, concentration for total growth inhibition: 100000 nM
Compound 3: middle estimate off by 2.0-fold (0.30 log units), on the low side; the range from low to high includes it.
By their numbers in this assay, from the lowest: compounds 2, 1 and 3 (each within the scatter of the next, the first and the last beyond it).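

In this assay acetylsulfamoyl in place of hydrogen on the six-membered aromatic ring of carbon only, para to a large group, gives a 1.6-fold higher number from compound 1 to compound 3 (0.20 log units; within the scatter) and so remains within the scatter of compound 1. This place on the core therefore takes an addition of 7 heavy atoms without a shift beyond the scatter. Nothing available explains this result.

Going by these compounds, whether an amine or a carboxylic acid at this place would move the number beyond the scatter stays open. So does whether any substituent here can bring a clear gain in growth inhibition.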